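A few compounds are considered here, and "the series" means these few. Any claim that something is new, unique, unknown or untested is made for them only; others in the source may bear on it.

Measured so far in an assay on Sf9 cells for inhibition of protein deacetylase HDAC6 (Homo sapiens), read by fluorescence, with a stated time of 90 min; on this read-out higher numbers stand for weaker inhibition and lower numbers for stronger inhibition:

Compound 1 `Cc1cc(C)cc(C(=O)N(CC(=O)NCc2ccccc2)Cc2ccc(C(=O)Nc3cc(F)ccc3N)cc2)c1`: > 10000 nM, a limit of the assay, not a number.
Compound 2 `Nc1ccccc1NC(=O)CCCCCN(CC(=O)NCc1ccccc1)C(=O)c1cccc2ccccc12`: > 10000 nM, again only a limit.
Compound 3 `Nc1ccccc1NC(=O)CCCCCN(CC(=O)NC1CCCCC1)C(=O)c1ccccc1`: > 10000 nM, again only a limit.

Where compound 1 stands: only a limit is known for it in this assay, and the other two compounds of the series show the same limit, so no ordering among the three can be drawn; all that is seen is the limit of > 10000 nM in this assay, at which 3 of the 3 values shown sit.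

The step followed here goes from compound 1 to compound 4 `Cc1cc(C)cc(C(=O)N(CC(=O)NCc2ccccc2)Cc2ccc(C(=O)Nc3ccccc3N)cc2)c1`. The change is hydrogen in place of fluoro on an aromatic carbon. For the measured compounds named here, no pair of measured compounds differs in one place, so no measured step sets the size of this change. With every value shown sitting at the limit, there is no number from which a direction could be read, and the change itself is small in what it removes.

The expectation is that compound 4 also reports a limit rather than a number, with an estimated value of 20000 nM (range 8000 nM to 60000 nM). The step this estimate implies, a step that the limit leaves unreadable from compound 1 to compound 4, is expected to lie within the scatter, in no direction beyond it.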

Compound 4, half-maximal inhibitory concentration: > 10000 nM
Compound 4 ended at the assay's limit; the forecaster's own chance of this, stated with the estimate: 80%; the middle value does not contradict the limit.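

In this assay, no step can be read from compound 1 to compound 4, since both results are limits of the assay and not numbers: the limit of > 10000 nM in this assay, at which 4 of the 4 values shown sit.

The compounds shown leave open whether hydrogen in place of fluoro on this aromatic carbon changes inhibition at all, and which structural change would yield a readable value.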